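Compound 4 at the Limit of a Cytotoxicity Assay

The compounds below may be only part of what the source reports. "The series", "measured", "known", "first", "only" and "open" are said of these compounds alone.

Of the compounds shown here, three sharing one core have been tested in an ADME assay on HEK-293T cells (Homo sapiens) for cytotoxicity, read by MTT assay, with a stated time of 48 h (a lower number here means that less compound is tolerated, a higher number that more compound is tolerated), so far. Compound 1 (`Cn1cc(C2CC(c3ccccc3)=NN2C(=O)c2cccnc2Cl)c2ccccc21`) gives > 300000 nM as a limit of the assay and not a number. Compound 2 (`COc1cc(C2=NN(C(=O)c3ccc(C)nc3)C(c3cn(C)c4ccccc34)C2)cc(OC)c1OC`) gives > 300000 nM as a limit too. Compound 3 (`Cn1cc(C2CC(c3ccc(Cl)cc3)=NN2C(=O)c2cccnc2)c2cc(Br)ccc21`) gives > 300000 nM as a limit as well. Compound 3 thus has no number of its own and stands at the limit of > 300000 nM in this assay, at which 3 of the 3 values shown sit, with nothing to rank it against the other two.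

Compound 4 (`COc1ccc(C2=NN(C(=O)c3cccnc3)C(c3cn(C)c4ccc(Br)cc34)C2)cc1OC`), not yet measured, carries 3,4-dimethoxyphenyl in place of 4-chlorophenyl on a carbon with a double bond to nitrogen. For the measured compounds named here, no measured pair shows what such a change does. The expectation therefore rests on compound 3 with its limit of > 300000 nM as the starting point. The expected change is a number no higher from compound 3 to compound 4 (the limit leaves the size open) in this assay and nothing beyond the usual scatter in either direction. Compound 4 is estimated at 300000 nM with an expected range from 120000 nM to 600000 nM and the assay may well report only a limit again.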

Compound 4, half-maximal cytotoxic concentration: > 300000 nM
Compound 4 gave a limit, no number; the forecaster's own chance of this, stated with the estimate: 80%; the middle value lies on the limit itself.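

For the compounds shown here, compound 3 and compound 4 both give a limit of the assay and not a number in this assay, so no step between them can be read: the limit of > 300000 nM in this assay, at which 4 of the 4 values shown sit. The compounds shown leave open at what concentration any of them becomes cytotoxic, and whether 3,4-dimethoxyphenyl in place of 4-chlorophenyl alters it.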